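Moving a methoxy group on the aryl ester of compound 3

The source may hold more compounds than are shown below. What is called first, only, known or untested is meant among the compounds shown, and "the series" means these compounds.

The shared core carries two ester groups, and the compounds differ in the group on one of them. In an ADME assay on a cell-free system (plasma, Homo sapiens) for metabolic stability, with Plasma (Rattus norvegicus) as the target, read by HPLC, at pH 7.4 (on this read-out higher numbers stand for a longer-lived compound and lower numbers for a shorter-lived compound), compound 1 `CC(=O)Oc1ccccc1C(=O)O[C@H]1CO[C@H]2[C@@H]1OC[C@H]2OC(=O)c1snnc1C` gives 0.0065 h, compound 2 `CC(=O)Oc1ccccc1C(=O)O[C@H]1CO[C@H]2[C@@H]1OC[C@H]2OC(=O)c1ccnn1C` gives 0.0642 h, and compound 3 `COc1ccccc1C(=O)O[C@@H]1CO[C@H]2[C@@H]1OC[C@@H]2OC(=O)c1ccccc1OC(C)=O` gives 0.0165 h, which places compound 3 second highest of the three: the step of a 2.5-fold higher number from compound 1 to compound 3 (0.40 log units; beyond the scatter) is modest, as is the step of a 3.9-fold lower number from compound 2 to compound 3 (0.59 log units; beyond the scatter) in the other direction. Compound 4 `COc1ccc(C(=O)O[C@@H]2CO[C@H]3[C@@H]2OC[C@@H]3OC(=O)c2ccccc2OC(C)=O)cc1` keeps every atom of compound 3 but joins them differently: 4-methoxyphenyl in place of 2-methoxyphenyl on a carbonyl carbon. Going by the values given here, no measured step covers a shift of a methoxy group within one ring; the steps of a 9.9-fold higher number from compound 1 to compound 2 (0.99 log units; beyond the scatter) and a 2.5-fold higher number from compound 1 to compound 3 (0.40 log units; beyond the scatter) only show that changing one ester group moves this assay modestly. With no closer guide, the step from compound 3 to compound 4 is expected to be small, a 1.2-fold higher number from compound 3 to compound 4 (0.08 log units; within the scatter), and compound 4 is estimated at 0.02 h in this assay, with a range from 0.008 h to 0.05 h.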

Compound 4, half-life: 0.0183 h
The estimate for compound 4 lay 1.1-fold (0.04 log units) above the measured number, within the range that was stated.
By their numbers in this assay, from the lowest: compound 1; then compounds 3 and 4 (each within the scatter of the next); then compound 2.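

Shifting the methoxy group within this ring, 4-methoxyphenyl in place of 2-methoxyphenyl on a carbonyl carbon, gives a 1.1-fold higher number from compound 3 to compound 4 (0.04 log units; within the scatter) in this assay, so for this pair the place of the methoxy group on the ring makes no readable difference. Replacing a ring of another kind does register, since a 3.5-fold lower number from compound 2 to compound 4 (0.55 log units; beyond the scatter) and a 2.8-fold higher number from compound 1 to compound 4 (0.45 log units; beyond the scatter) show the 4-methoxyphenyl compound lying on opposite sides of the two compounds with five-membered rings, much as the 2-methoxyphenyl compound does. Nothing available here explains the size of any of these steps.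

From the compounds shown here alone, it remains open whether a phenyl ring carrying an amine or a carboxylic acid in place of the methoxy group would also leave the number within the scatter. The same question stands for a longer chain such as ethoxy, or for a plain phenyl group with nothing on the ring.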